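Chalcone-triazole amides: cross of two side chains

The source may hold more compounds than are shown below. What is called first, only, known or untested is meant among the compounds shown, and "the series" means these compounds.

Measured:
compound 1 `CCCCCCCCn1cc(/C=C/C(=O)c2ccc(NC(=O)CN3CCN(c4ccccc4)CC3)cc2)nn1` — 41400 nM
compound 2 `O=C(CN1CCC(Cc2ccccc2)CC1)Nc1ccc(C(=O)/C=C/c2cn(Cc3ccc(Br)cc3)nn2)cc1` — 42900 nM
compound 3 `CC(C)(C)OC(=O)N1CCN(CC(=O)Nc2ccc(C(=O)/C=C/c3cn(Cc4ccc(Br)cc4)nn3)cc2)CC1` — 25800 nM

All values come from a functional assay on SK-N-SH cells (Homo sapiens) for inhibition, read by MTT assay; a higher number here means a weaker inhibitor, a lower number a stronger inhibitor. Compound 2 carries the highest number of the set, but its gap to compound 1 and its gap to compound 3 both lie within the scatter, so no order among the measured compounds can be read from these numbers. Among the measured compounds shown here, compounds 1 and 2 differ in two places at once and no single step between them is available; their values simply show that an octyl chain with a phenylpiperazine amide and a 4-bromobenzyl group with a benzylpiperidine amide land in the same range in this assay.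

Compound 4 `CCCCCCCCn1cc(/C=C/C(=O)c2ccc(NC(=O)CN3CCC(Cc4ccccc4)CC3)cc2)nn1` is not yet measured. It is compound 2 with heptyl in place of 4-bromophenyl on a saturated chain carbon bound to an aromatic nitrogen; cut one bond further out, this reads 4-bromobenzyl to octyl, which brings the chain of compound 1 onto the amide side of compound 2. With compounds 1 and 2 within the scatter of each other, nothing in hand points to a change beyond the scatter in either direction.

The step from compound 2 to compound 4 is expected to be about a 1.1-fold lower number from compound 2 to compound 4 (0.03 log units; within the scatter). For compound 4 the estimate in this assay is 40000 nM, with a range from 15000 nM to 110000 nM.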

Compound 4, half-maximal inhibitory concentration: 57000 nM
The estimate for compound 4 lay 1.4-fold (0.15 log units) below the measured number; measured number inside the range.
By their numbers in this assay, from the lowest: compounds 3, 1, 2 and 4 (each within the scatter of the next, the first and the last beyond it).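

Notes on the position bearing the aromatic nitrogen's saturated chain carbon: with the benzylpiperidine amide held fixed, replacing 4-bromobenzyl with octyl gives a 1.3-fold higher number from compound 2 to compound 4 (0.12 log units; within the scatter) in this assay, and this is the first single-place reading for this position in the series, since compound 1 and compound 2 differ in two places at once. The 4-bromophenyl part, with its aromatic ring and bromine, can therefore give way to an open heptyl chain without a difference that can be read beyond the scatter, so neither the ring nor the bromine shows up as a requirement here, at least on this one amide side. No measurement at hand speaks to the reason for this outcome.

From the compounds shown here alone, whether a chain ending in an amine or a carboxylic acid, or a longer chain such as dodecyl, would stay in the same range at this position remains open. Going by these compounds, it is also open whether the same exchange of 4-bromobenzyl for octyl would read the same way on the amide side of compound 3.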